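The compounds below may be only part of what the source reports. "The series", "measured", "known", "first", "only" and "open" are said of these compounds alone.

Measured in an ADME assay on HEK-293T cells (Homo sapiens) for cytotoxicity, read by luminescence, with a stated time of 24 h; on this read-out lower numbers stand for higher toxicity in this test and higher numbers for lower toxicity in this test:
- Compound 1 `COc1ccc(Cn2c(C(=O)N3CCC(C(N)=O)CC3)cc3sccc32)cc1`: > 100000 nM
- Compound 2 `COc1ccc(Cn2c(C(=O)N3CCN(Cc4ccccc4)CC3)c(CNC(C)c3ccccc3)c3sccc32)cc1`: > 100000 nM
- Compound 3 `CCCNCc1cc2c(cc(C(=O)N3CCC(C(=O)NCCC)CC3)n2Cc2ccc(OC)cc2)s1`: > 100000 nM

Each of these entries is a limit of the test and not a number. Compound 3 therefore has no exact position, and the overall picture is the limit of > 100000 nM in this assay, at which 3 of the 3 values shown sit.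

Compound 4 `CCCNC(=O)C1CCN(C(=O)c2cc3sc(C#N)cc3n2Cc2ccc(OC)cc2)CC1` carries cyano in place of (propylamino)methyl on an aromatic carbon, next to the ring sulfur (cyano in place of (propylamino)methyl on an aromatic carbon).

Going by the values given here, no measured pair differs in one place only, so this change has no direct precedent. Because of the limit of > 100000 nM in this assay, at which 3 of the 3 values shown sit, which includes compound 3, no step beyond the scatter is expected in this assay, in either direction.

The step expected is a number no higher from compound 3 to compound 4 (the limit leaves the size open).

The estimated value for compound 4 is 100000 nM, with an expected range from 50000 nM to 100000 nM.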

Compound 4, half-maximal cytotoxic concentration: > 100000 nM
Compound 4: a limit, no number; the forecaster's own chance of this, stated with the estimate: 80%; the middle value sits exactly at the limit.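

No step can be read between compound 3 and compound 4 in this assay, because both results are limits of the test: the limit of > 100000 nM in this assay, at which 4 of the 4 values shown sit. The compounds shown leave open whether cyano in place of (propylamino)methyl changes toxicity, and at what concentration any of them becomes toxic.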